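A few compounds are considered here, and "the series" means these few. Any claim that something is new, unique, unknown or untested is made for them only; others in the source may bear on it.

Measured in a functional assay on SMMC-7721 cells (Homo sapiens) for cytotoxicity, read by MTT assay, with a stated time of 24 h; on this read-out higher numbers stand for weaker inhibition and lower numbers for stronger inhibition:
- compound 1 `O=C1/C(=C/c2ccccc2F)CN(S(=O)(=O)c2ccc(O[N+](=O)[O-])cc2)C/C1=C\c1ccccc1F` gives 6200 nM
- compound 2 `O=C1/C(=C/c2ccccc2F)CN(S(=O)(=O)c2ccc(C(F)(F)F)cc2)C/C1=C\c1ccccc1F` gives 5200 nM
- compound 3 `O=C1/C(=C/c2ccccc2F)CN(S(=O)(=O)c2ccc(F)cc2)C/C1=C\c1ccccc1F` gives 7700 nM

Compound 3 has the highest of the three numbers, though its nearest neighbour compound 1 and furthest neighbour compound 2 both sit within the scatter of it. Compound 4 `O=C1/C(=C/c2ccccc2F)CN(S(=O)(=O)c2ccc(Br)cc2)C/C1=C\c1ccccc1F` differs from compound 3 by bromo in place of fluoro on an aromatic carbon. Within the data shown here, no measured step carries bromo, but every change at that aromatic carbon so far has stayed flat: a 1.2-fold lower number from compound 1 to compound 2 (0.08 log units; within the scatter), a 1.2-fold higher number from compound 1 to compound 3 (0.09 log units; within the scatter), a 1.5-fold higher number from compound 2 to compound 3 (0.17 log units; within the scatter). On that basis the step of a 1.1-fold lower number from compound 3 to compound 4 (0.04 log units; within the scatter) is expected to be no larger than the scatter, in no settled direction. Compound 4 is therefore estimated at 7000 nM in this assay, within 3500 nM to 14000 nM.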

Compound 4, half-maximal inhibitory concentration: 5200 nM
The estimate for compound 4 lay 1.3-fold (0.13 log units) above the measured number; the measured number falls inside the stated range.
By their numbers in this assay, from the lowest: compounds 2, 4, 1 and 3 (each within the scatter of the next).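

In this assay, bromo at this aromatic carbon, para to a large group, joins a flat run: a 1.5-fold lower number from compound 3 to compound 4 (0.17 log units; within the scatter) and no change at the digits printed from compound 2 to compound 4 (within the scatter) and a 1.2-fold lower number from compound 1 to compound 4 (0.08 log units; within the scatter) all lie within the scatter. Nitrooxy, trifluoromethyl, fluoro and bromo at this carbon now give numbers that cannot be told apart, so the swap of fluoro for bromo adds no separation to the series.

Going by these compounds, whether an amine or a carboxylic acid at this carbon would leave that run intact stays open, as does the effect of changes elsewhere on the shared core. No measurement here offers an explanation for the flat run.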